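Methoxy to Methyl on the Pyrazoline Aryl: Compound 4

The source may report more compounds than this note shows. Statements on the series, on what has been measured and on what is new or still open speak of the compounds shown alone.

Compound 1: `O=C(CBr)N1N=C(c2ccc(F)cc2)CC1c1ccccc1O`, 6000 nM
Compound 2: `Cc1ccc(C2=NN(C(=O)CBr)C(c3cc(Cl)ccc3O)C2)cc1`, 5220 nM
Compound 3: `COc1ccc(C2=NN(C(=O)CN3CCCCC3)C(c3ccccc3O)C2)cc1`, 12700 nM

The three compounds were tested in an assay on isolated protein for inhibition of Amine oxidase [flavin-containing] A (Homo sapiens), read by fluorescence, with stated times of 15 min and 20 min; on this read-out lower numbers stand for stronger inhibition and higher numbers for weaker inhibition. They share a core carrying two aromatic rings and an acyl group on the ring nitrogen; they differ in the substituent on the first aromatic ring and in the acyl group. Among the three, compound 3 gives the highest number, that is the weakest inhibition: its value of 12700 nM stands beyond the usual scatter from both compound 1 and compound 2, whose values sit closer to each other than either does to compound 3.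

Compound 4 is `Cc1ccc(C2=NN(C(=O)CN3CCCCC3)C(c3ccccc3O)C2)cc1` and has not yet been measured in this assay. It comes from compound 3 by a single change: methyl in place of methoxy on an aromatic carbon. The piperidinyl-acetyl group and the unsubstituted hydroxyphenyl ring stay as they are.

Among the measured compounds shown here, no pair of the measured compounds differs by exactly this change, so nothing measured tells the size of the step directly. Swapping methoxy for methyl on an aromatic carbon is a small change, and a step no larger than the usual scatter is expected, without a clear direction. Compound 4 is therefore estimated at 9500 nM, with a range from 3500 nM to 26000 nM. The expected step from compound 3 to compound 4 is a 1.3-fold lower number from compound 3 to compound 4 (0.13 log units; within the scatter).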

Compound 4, half-maximal inhibitory concentration: 11300 nM
Compound 4: middle estimate off by 1.2-fold (0.08 log units), on the low side; low and high end bracket the measured number.
By their numbers in this assay, from the lowest: compounds 2, 1, 4 and 3 (each within the scatter of the next, the first and the last beyond it).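

In this assay, among the compounds shown here, replacing 4-methoxyphenyl with 4-methylphenyl gives a 1.1-fold lower number from compound 3 to compound 4 (0.05 log units; within the scatter), the first direct reading of a change at this position, on the aromatic ring and para to a large group. The two compounds cannot be told apart here, so this swap, which removes an oxygen and with it a hydrogen-bond acceptor, leaves no detectable mark on the read-out with the piperidinyl-acetyl group and unsubstituted hydroxyphenyl ring in place. Nothing available explains why the swap has so little effect.

From the compounds shown here alone, this single pair covers only methoxy and methyl, so it remains open whether an amine, a carboxylic acid or a longer chain such as butoxy at the same position would also leave the number within the scatter. Going by these compounds, it is also open whether the same swap would give so small a step with a different acyl group on the ring nitrogen, such as the bromoacetyl group of compound 1, or with a substituent on the hydroxyphenyl ring, such as the chlorine of compound 2.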